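The compounds below may be only part of what the source reports. "The series", "measured", "known", "first", "only" and "open" are said of these compounds alone.

Compound 2 `CCCCCCCCc1ccc(OCC(=O)Cn2nnnc2-c2ccc(Cl)cc2)cc1` gives 130 nM in an assay on microsomes from brain for inhibition of Fatty-acid amide hydrolase 1 (Rattus norvegicus), read by fluorescence and HPLC, with a stated time of 60 min (on this read-out lower numbers stand for stronger inhibition and higher numbers for weaker inhibition), the higher of the two numbers recorded so far. Within the data shown here, its nearest neighbour is compound 1 `CCCCCCCCc1ccc(OCC(=O)Cn2nnnc2SC)cc1`, which in this assay gives 22 nM; the only measured step, a 5.9-fold higher number from compound 1 to compound 2 (0.77 log units; beyond the scatter), arose from 4-chlorophenyl in place of methylsulfanyl on an aromatic carbon and lies beyond the scatter.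

Compound 3 `CCCCCCCCc1ccc(OCC(=O)Cn2nnnc2-c2ccccc2Cl)cc1` differs from compound 2 by 2-chlorophenyl in place of 4-chlorophenyl on an aromatic carbon. Among the measured compounds shown here, no measured step concerns where the chlorine sits on this phenyl ring: the step from compound 1 to compound 2 changed the whole group, not the position of a substituent on it, so it bears on the present change only loosely. Without a direct precedent, compound 3 is expected to sit close to compound 2, with a 1.2-fold higher number from compound 2 to compound 3 (0.06 log units; within the scatter) not beyond the scatter. The estimate for compound 3 in this assay is 150 nM, within a range of 45 nM to 500 nM.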

Compound 3, half-maximal inhibitory concentration: 4600 nM
The estimate for compound 3 lay 31-fold (1.49 log units) below the measured number, and the stated range ends below it.
By their numbers in this assay, from the lowest: compound 1; then compound 2; then compound 3.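

In this assay, moving the chlorine on the phenyl ring, with the group's atoms unchanged, produces a 35-fold higher number from compound 2 to compound 3 (1.55 log units; beyond the scatter) and so counts for more at this position than the exchange of the whole group did in a 5.9-fold higher number from compound 1 to compound 2 (0.77 log units; beyond the scatter). The number therefore depends strongly on where the chlorine sits, not only on which group occupies this aromatic carbon. Measured against the methylsulfanyl compound, 2-chlorophenyl gives a 210-fold higher number from compound 1 to compound 3 (2.32 log units; beyond the scatter) and is thus far less tolerated there than 4-chlorophenyl; nothing available explains this difference.

The compounds shown leave open whether the loss belongs to chlorine itself or to any group at that place on the phenyl ring, which 2-fluorophenyl or 2-methylphenyl would address. Unsubstituted phenyl and 3-chlorophenyl would show how the number changes between the two chlorinated compounds.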